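Replacing 4-cyanophenyl with thiophen-2-yl in a stable compound

This account rests on a few compounds, and the source may have more. Where it says the series, first, only, none or still open, it means among the compounds named here.

compound 1 `COc1ccc(-c2c(C)oc3c(N4CC[C@@H](NC(C)=O)C4)cc(C)nc23)cc1OC`: > 95%
compound 2 `COc1ccc(-c2scc3c(N4CC[C@@H](NC(C)=O)C4)nc(C)nc23)cc1OC`: > 95%
compound 3 `CC(=O)N[C@@H]1CCN(c2cc(C)nn3c(-c4ccc(C#N)cc4)c(C)nc23)C1`: > 95%

All three compounds were tested in an ADME assay on microsomes from liver (Homo sapiens) for metabolic stability, read by LC-MS, with NADPH named in the record, with a stated time of 60 min, tested at 1 uM, in the absence of a further agent; on this read-out higher numbers stand for a more stable compound and lower numbers for a less stable compound. Compound 3 gives > 95%, which is a limit of the assay and not a number. The whole set looks the same, with the limit of > 95% in this assay, at which 3 of the 3 values shown sit. Among the measured compounds shown here, no measured step between these compounds is available, so the data offer no direct guide to the size of a change.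

Compound 4 `CC(=O)N[C@@H]1CCN(c2cc(C)nn3c(-c4cccs4)c(C)nc23)C1` carries thiophen-2-yl in place of 4-cyanophenyl on an aromatic carbon, the same place where compound 3 bears its group: thiophen-2-yl in place of 4-cyanophenyl on an aromatic carbon. As far as these compounds go, its value in this assay is still open. With only a limit as the starting point, the direction can only be downward or flat, and compound 4 may itself stop at the limit. The expected change is a number at least 10 percentage points lower from compound 3 to compound 4 (that floor lies within the scatter), a modest step that may stay close to the usual scatter. For compound 4 the estimated value is 85%, with an expected range of 60% to 98%.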

Compound 4, percent of the compound remaining: > 95%
Compound 4 ended at the assay's limit; the forecaster's own chance of this, stated with the estimate: 40%; at least 10 percentage points between middle value and limit.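

Compound 3 and compound 4 both stop at the limit of this assay, so no step between them can be read: the limit of > 95% in this assay, at which 4 of the 4 values shown sit.

The compounds shown leave open whether thiophen-2-yl and 4-cyanophenyl differ at all in this assay, and what would bring a value off that limit.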